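The source may hold more compounds than are shown below. What is called first, only, known or untested is meant among the compounds shown, and "the series" means these compounds.

Among the measured compounds shown here, in a functional assay on PC-3 cells (Homo sapiens) for antiproliferative activity, read by MTT assay (on this read-out higher numbers stand for weaker inhibition and lower numbers for stronger inhibition), compound 3 `Cn1c(=O)c(=O)n(C2CCCC2)c2nc(N/N=C/c3cccs3)ncc21` gives 75600 nM, the highest of the three numbers measured so far. Compound 2 `Cn1c(=O)c(=O)n(C2CCCC2)c2nc(N/N=C/c3ccco3)ncc21` gives 72200 nM, and a 1.0-fold higher number from compound 2 to compound 3 (0.02 log units; within the scatter). Compound 1 `Cn1c(=O)c(=O)n(C2CCCC2)c2nc(N/N=C/c3ccc(F)c(Cl)c3)ncc21` gives 8550 nM; the steps of an 8.4-fold higher number from compound 1 to compound 2 (0.93 log units; beyond the scatter) and an 8.8-fold higher number from compound 1 to compound 3 (0.95 log units; beyond the scatter) are the only ones beyond the scatter. Compound 4 `Cc1ccc(/C=N/Nc2ncc3c(n2)n(C2CCCC2)c(=O)c(=O)n3C)cc1C` arises from compound 3 by 3,4-dimethylphenyl in place of thiophen-2-yl on a carbon with a double bond to nitrogen. The measured step that bears on this is an 8.8-fold higher number from compound 1 to compound 3 (0.95 log units; beyond the scatter), which likewise exchanges a five-membered aromatic ring with one hetero atom for a six-membered aromatic ring of carbon only, and read in reverse it points to a lower number. Compound 4 is expected to show a 6.3-fold lower number from compound 3 to compound 4 (0.80 log units; beyond the scatter), with some allowance for the different substituents on the ring. The estimate for compound 4 is 12000 nM, with a range from 4000 nM to 40000 nM.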

Compound 4, half-maximal inhibitory concentration: 39000 nM
Estimate against measurement, compound 4: 3.3-fold (0.51 log units) below; the measured number falls inside the stated range.
By their numbers in this assay, from the lowest: compound 1; then compounds 4, 2 and 3 (each within the scatter of the next).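

In this assay there is a 1.9-fold lower number from compound 3 to compound 4 (0.29 log units; within the scatter) and a 1.9-fold lower number from compound 2 to compound 4 (0.27 log units; within the scatter) so a six-membered aromatic ring of carbon only, as 3,4-dimethylphenyl, does not separate from the five-membered rings at this place. With a 4.6-fold higher number from compound 1 to compound 4 (0.66 log units; beyond the scatter) still standing, the lower number of compound 1 goes with 3-chloro-4-fluorophenyl and not with a phenyl ring as such. Nothing available explains this difference. The compounds shown leave open whether the chlorine or the fluorine alone accounts for it. They also leave open how an amine or a carboxylic acid on the phenyl ring would read.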